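A few compounds are considered here, and "the series" means these few. Any claim that something is new, unique, unknown or untested is made for them only; others in the source may bear on it.

Series notes. Compound 1 `O=C(NCc1ccc(F)cc1)c1nc(Br)c2cccnc2c1NCc1ccccc1` is the reference point for this step and has been run in a functional assay on MDA-MB-435 cells (Homo sapiens) for cytotoxicity, read by MTT assay, with a stated time of 72 h; a higher number here means a weaker inhibitor, a lower number a stronger inhibitor. In this assay compound 1 gives > 20000 nM, which is a limit of the measurement and not a number. Compound 2 `O=C(NCc1ccc(F)cc1)c1nc(NCCO)c2cccnc2c1O` carries a different substitution pattern on the shared core. In this assay compound 2 gives > 20000 nM, again a limit rather than a number. Where compound 1 stands is therefore fixed only by the limit of > 20000 nM in this assay, at which 2 of the 2 values shown sit; no numbered value exists in the set, and no step between two measured compounds can be drawn.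

Compound 3 `CN(C)CCCNc1c(C(=O)NCc2ccc(F)cc2)nc(Br)c2cccnc12` is the next member, not yet measured in this assay. It differs from compound 1 by 2-(dimethylamino)ethyl in place of phenyl on a saturated chain carbon bound to a nitrogen on an aromatic ring. With both measured values sitting at a limit, the data give no direction for this change, and the step it implies is expected to be none beyond the scatter, written as a number no higher from compound 1 to compound 3 (the limit leaves the size open). For compound 3 the estimate in this assay is 20000 nM, within 6000 nM to 60000 nM, with a strong chance that only a limit is again reported.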

Compound 3, half-maximal inhibitory concentration: 7000 nM
The estimate for compound 3 lay 2.9-fold (0.46 log units) above the measured number; measured number inside the range.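

Among the compounds shown here, this position is the first where a change moves the read-out off the limit: in this assay, 2-(dimethylamino)ethyl in place of phenyl on a saturated chain carbon bound to a nitrogen on an aromatic ring gives an at least 2.8-fold lower number from compound 1 to compound 3 (0.45 log units; beyond the scatter). For the compounds shown here, compound 3 supplies the only numbered value in the set, 7000 nM, so later changes at this position now have a number to be read against. As far as these compounds go, the true size of the step stays open because the entry for compound 1 is a limit and not a number: the limit of > 20000 nM in this assay, at which 2 of the 3 values shown sit.

The step swaps an aromatic ring for a chain that carries a nitrogen, so the compounds shown cannot tell whether the change in the read-out follows the loss of the ring, the arrival of the dimethylamino group, or both. A plain propyl chain with no amine, or a longer chain ending in a morpholine, would be the kind of group needed to separate these readings.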